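The source may hold more compounds than are shown below. What is called first, only, known or untested is meant among the compounds shown, and "the series" means these compounds.

Measured so far in a functional assay on HeLa cells (Homo sapiens) for cytotoxicity, read by MTT assay, with a stated time of 72 h; on this read-out higher numbers stand for weaker inhibition and lower numbers for stronger inhibition:
- compound 1 `CCOC(=O)c1csc2nc(-c3cccc(NC(=O)c4ccco4)c3)cn12`: > 20000 nM, a limit of the assay rather than a number.
- compound 2 `CCOC(=O)c1csc2nc(-c3ccc(NC(=O)CC)cc3)cn12`: > 20000 nM, likewise a limit rather than a number.

Compound 2 therefore stands nowhere in particular on the numbers shown: it is only known to sit at the limit, and the same holds for the other measured compound, so no ordering between the two is possible. The evidence is summed up by the limit of > 20000 nM in this assay, at which 2 of the 2 values shown sit.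

The next compound, compound 3 `CCOC(=O)c1csc2nc(-c3ccc(NC(=O)Nc4ccc(Br)cn4)cc3)cn12`, differs from compound 2 in one place: (5-bromopyridin-2-yl)amino in place of ethyl on a carbonyl carbon. Cut one bond further out, the change reads propanoyl to (5-bromopyridin-2-yl)carbamoyl, so the acyl amide of compound 2 becomes a urea carrying a bromopyridinyl group.

Among the compounds with values here, no step between measured compounds exists in this assay, so no size of effect can be read off the data. With the starting point itself undetermined beyond the limit, the step from compound 2 to compound 3 is expected to be a step that the limit leaves unreadable from compound 2 to compound 3, that is, nothing that can be told apart from the scatter. Compound 3 is accordingly expected to give about 25000 nM, within roughly 5000 nM to 60000 nM, with a real chance that only a limit is reported again.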

Compound 3, half-maximal inhibitory concentration: > 20000 nM
Compound 3 gave a limit, no number (the forecaster's own chance of this, stated with the estimate: 70%); the middle value is on the limit's open side.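

Compound 2 and compound 3 both give only a limit in this assay, so no step can be read for the change from propanoyl to (5-bromopyridin-2-yl)carbamoyl. The compounds shown leave open how far any of them lies past that limit, and which structural changes would bring a readable number in this assay: the limit of > 20000 nM in this assay, at which 3 of the 3 values shown sit.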